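The source may hold more compounds than are shown below. What is called first, only, known or untested is meant among the compounds shown, and "the series" means these compounds.

Compound 3, `Cc1nn(-c2ccccc2Cl)c2c1C(c1ccc(Oc3ccccc3)cc1)SC(C)C(=O)N2`, gives 2700 nM in an assay on isolated protein for agonist activity at Bile acid receptor (Homo sapiens), read by AlphaScreen, with a stated time of 30 min; on this read-out higher numbers stand for an effect only at larger amounts of compound and lower numbers for an effect already at smaller amounts. Among the three compounds measured it holds the second highest number: compound 1, `COc1ccccc1-n1nc(C)c2c1NC(=O)[C@H](C)S[C@@H]2c1ccc(Oc2ccccc2)cc1`, gives 3300 nM, which lies within the scatter of compound 3, while compound 2, `Cc1nn(-c2ccccc2I)c2c1C(c1ccc(Oc3ccccc3)cc1)SC(C)C(=O)N2`, gives 1300 nM, and the step of a 2.1-fold higher number from compound 2 to compound 3 (0.32 log units; beyond the scatter) lies beyond the scatter. The unmeasured compound 4, `Cc1nn(-c2ccccc2C(F)(F)F)c2c1C(c1ccc(Oc3ccccc3)cc1)SC(C)C(=O)N2`, differs from compound 3 only in that (trifluoromethyl in place of chloro on an aromatic carbon). Among the compounds with values here, the single measured step that bears on this place is the exchange of iodo for chloro, a 2.1-fold higher number from compound 2 to compound 3 (0.32 log units; beyond the scatter), a modest change from one halogen to another on the same aromatic carbon. Within the data shown here, no measured pair shows a trifluoromethyl at this place, so the direction of the new step rests on that one comparison alone. Since the exchange of halogens moved the number only modestly, the change to trifluoromethyl is expected to stay within a similarly small range, in either direction, and most likely not beyond the scatter. On this reasoning compound 4 is expected to give about 2200 nM in this assay, with a range from 800 nM to 6000 nM, meaning an expected step of a 1.2-fold lower number from compound 3 to compound 4 (0.09 log units; within the scatter).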

Compound 4, half-maximal effective concentration: 2000 nM
For compound 4 the middle estimate is 1.1-fold (0.04 log units) above the measured one, and the stated range covers the measured number.
By their numbers in this assay, from the lowest: compounds 2, 4, 3 and 1 (each within the scatter of the next, the first and the last beyond it).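

In this assay, trifluoromethyl in place of chloro on this aromatic carbon, ortho to a large group, gives a 1.4-fold lower number from compound 3 to compound 4 (0.13 log units; within the scatter), and the same place with trifluoromethyl in place of iodo gives a 1.5-fold higher number from compound 2 to compound 4 (0.19 log units; within the scatter). Both steps lie within the scatter, so compound 4 cannot be told apart from either halogen compound, even though the step between the two halogens, a 2.1-fold higher number from compound 2 to compound 3 (0.32 log units; beyond the scatter), lies just beyond it. The earlier compounds showed only an exchange of one halogen for another, whereas this result shows that a non-halogen group of 4 heavy atoms can enter here in place of a single atom and leave the number in the same range, and no measurement at hand offers an explanation for this.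

The compounds shown leave open whether this place needs a group at all, since a plain hydrogen does not appear here. They also leave open whether an amine, a hydroxyl or a carboxylic acid at the same carbon would stay in this range or move the number well beyond the scatter.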